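The source may hold more compounds than are shown below. What is called first, only, known or untested is meant among the compounds shown, and "the series" means these compounds.

Three compounds share one core and differ only in a single group on one six-membered ring. For the measured compounds named here, in a functional assay on cells (Splenocyte, Mus musculus, strain BALB/c) for inhibition, read by scintillation counting and thymidine incorporation, with stated times of 48 h and 8 h (on this read-out higher numbers stand for weaker inhibition and lower numbers for stronger inhibition), compound 2 `Fc1ccc(-c2noc(Cc3c[nH]c4ccccc34)n2)cc1` gives 13600 nM, the only measured number here. Compound 1 `c1ccc(-c2noc(Cc3c[nH]c4ccccc34)n2)cc1` reaches only the limit > 50000 nM. Compound 3 `O=[N+]([O-])c1ccc(-c2noc(Cc3c[nH]c4ccccc34)n2)cc1` likewise stops at the limit > 50000 nM. Two of the three values thus sit at the limit of > 50000 nM in this assay, at which 2 of the 3 values shown sit. The measured steps read an at least 3.6-fold lower number from compound 1 to compound 2 (0.56 log units; beyond the scatter) and an at least 3.6-fold higher number from compound 2 to compound 3 (0.56 log units; beyond the scatter), while a step that the two limits leave unreadable from compound 1 to compound 3. Compound 4 `CCc1ccc(-c2noc(Cc3c[nH]c4ccccc34)n2)cc1` is the compound still to be measured; its change from compound 2 is ethyl in place of fluoro on an aromatic carbon. Neither measured step involves ethyl, so the direction is uncertain, but a modest weakening beyond the scatter is expected, a 1.8-fold higher number from compound 2 to compound 4 (0.26 log units; within the scatter). Compound 4 is therefore estimated at about 25000 nM in this assay, between 8000 nM and 60000 nM.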

Compound 4, half-maximal inhibitory concentration: 13900 nM
Beside the measured number, compound 4's estimate is 1.8-fold (0.25 log units) above it; low and high end bracket the measured number.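

Putting ethyl in place of fluoro leaves the read-out unchanged (a 1.0-fold higher number from compound 2 to compound 4 (0.01 log units; within the scatter)), so a small carbon chain serves this position as well as fluoro does. Ethyl also keeps the advantage over hydrogen (an at least 3.5-fold lower number from compound 1 to compound 4 (0.55 log units; beyond the scatter)) and over nitro (an at least 3.5-fold lower number from compound 3 to compound 4 (0.55 log units; beyond the scatter)), so a group here does not by itself decide the outcome. Compound 1 and compound 3 each stand at a limit, not a number. From the compounds shown here alone, whether a longer chain such as butyl would hold this level remains open. So does what methoxy or an amine would do here.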